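Methyl in Place of Chloro on a Shared Core

This account rests on a few compounds, and the source may have more. Where it says the series, first, only, none or still open, it means among the compounds named here.

Of the compounds shown here, two measured so far share one core and differ only in the substituent on the outer phenyl ring. Compound 1 `CS(=O)(=O)c1ccc(-c2cnc3[nH]cc(-c4nnc(-c5ccc(F)cc5)o4)c(=O)c3c2)cc1` carries fluoro there, and in a functional assay on HCT-116 cells (Homo sapiens) for inhibition, read by MTT assay, with a stated time of 24 h, tested at 5 uM (a higher number here means more inhibition of growth at the concentration tested, a lower number less inhibition of growth), compound 1 gives 14.9%. Compound 2 `CS(=O)(=O)c1ccc(-c2cnc3[nH]cc(-c4nnc(-c5ccc(Cl)cc5)o4)c(=O)c3c2)cc1` carries chloro, and in this assay compound 2 gives 16.4%. The step of a number 1.5 percentage points higher from compound 1 to compound 2 (within the scatter) is within the scatter. Among the two numbers compound 2 stands at the top, with compound 1 nearest to it, the gap again within the scatter.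

Compound 3 `Cc1ccc(-c2nnc(-c3c[nH]c4ncc(-c5ccc(S(C)(=O)=O)cc5)cc4c3=O)o2)cc1` is not yet measured. Relative to compound 2 the change is methyl in place of chloro on an aromatic carbon. Within the data shown here, the only measured step that bears on this position is the halogen exchange a number 1.5 percentage points higher from compound 1 to compound 2 (within the scatter), which moved the number by an amount inside the scatter. On that basis the step of a number 1.4 percentage points lower from compound 2 to compound 3 (within the scatter) is expected to be none beyond the scatter. The estimate for compound 3 in this assay is therefore 15%, with a range from 5% to 26%.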

Compound 3, percent growth inhibition at one concentration: 20.4%
Beside the measured number, compound 3's estimate is 5.4 percentage points below it, within the range that was stated.
By their numbers in this assay, from the lowest: compounds 1, 2 and 3 (each within the scatter of the next).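

Replacing the halogen with a carbon group at this position, on an aromatic carbon para to a large group, gives a number 4 percentage points higher from compound 2 to compound 3 (within the scatter) in this assay, and the change from 4-chlorophenyl to 4-methylphenyl therefore cannot be told from scatter. Set against the other halogen, the same replacement gives a number 5.5 percentage points higher from compound 1 to compound 3 (within the scatter) and again stays inside the scatter, so fluoro, chloro and methyl, each a single heavy atom, cannot be separated at this position, and none of the three compounds can be ranked above another. The earlier pair had shown this only for one halogen against another, whereas the position now also tolerates a substituent that is not a halogen without any readable shift in growth inhibition, and nothing at hand explains how close these numbers lie.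

The compounds shown leave open whether an amine, a carboxylic acid or a longer chain such as butyl on this same carbon would give a step beyond the scatter. They also leave open whether fluoro, chloro and methyl would remain this close in a different cell line or at another concentration.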